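The source may report more compounds than this note shows. Statements on the series, on what has been measured and on what is new or still open speak of the compounds shown alone.

Measured compounds in an assay on isolated protein with Bile acid receptor (Homo sapiens) as the target; a lower number here means that less compound is needed, a higher number that more compound is needed for the effect:

Compound 1, `CCOC(=O)/C=C/c1ccc(CN(C(=O)C2CCCCC2)c2cccc(/C=C/C(=O)OC)c2)cc1` — in this assay compound 1 reaches only the limit of > 1000 nM, which is a limit and not a number.
Compound 2, `COC/C=C/c1ccc(CN(C(=O)C2CCCCC2)c2cccc(/C=C/C(=O)OC)c2)cc1` — compound 2 gives 233 nM.
Compound 3, `COC(=O)/C=C/c1cccc(N(Cc2ccc(/C=C/c3cccc(Cl)c3)cc2)C(=O)C2CCCCC2)c1` — compound 3 gives 165 nM.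

Compound 3 therefore holds the lowest of the two numbers shown, but its nearest neighbour is close: the step of a 1.4-fold lower number from compound 2 to compound 3 (0.15 log units; within the scatter) lies within the scatter, so no order between compound 2 and compound 3 can be claimed. Compound 1 contributes only a limit (the limit of > 1000 nM in this assay, at which 1 of the 3 values shown sits).

Compound 4 is `COC(=O)/C=C/c1cccc(N(Cc2ccc(/C=C/c3ccc(F)cc3)cc2)C(=O)C2CCCCC2)c1`. It differs from compound 3 by 4-fluorophenyl in place of 3-chlorophenyl on a double-bonded chain carbon bound to a double-bonded chain carbon. Going by the values given here, two measured steps touch this position: an at least 6.0-fold lower number from compound 1 to compound 3 (0.78 log units; beyond the scatter) and a 1.4-fold lower number from compound 2 to compound 3 (0.15 log units; within the scatter). Both replace a non-aromatic group with the 3-chlorophenyl; neither exchanges one halogenated phenyl for another, so they give no direct measure of the present change. The closest analogy, the step from compound 2 to compound 3, was within the scatter. Compound 4 is thus expected to sit near compound 3, with a step of a 1.2-fold higher number from compound 3 to compound 4 (0.08 log units; within the scatter) not beyond the scatter. Compound 4 is estimated at 200 nM, between 70 nM and 600 nM.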

Compound 4, half-maximal effective concentration: 185 nM
Estimate against measurement, compound 4: 1.1-fold (0.03 log units) above; measured number inside the range.
By their numbers in this assay, from the lowest: compounds 3, 4 and 2 (each within the scatter of the next). At a limit, above all of these: compound 1.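

In this assay, exchanging one halogenated phenyl for another on a double-bonded chain carbon bound to a double-bonded chain carbon gives a 1.1-fold higher number from compound 3 to compound 4 (0.05 log units; within the scatter), within the scatter, so 3-chlorophenyl and 4-fluorophenyl cannot be told apart here. The step of a 1.3-fold lower number from compound 2 to compound 4 (0.10 log units; within the scatter) is also within the scatter, which leaves 4-fluorophenyl and methoxymethyl unseparated, while an at least 5.4-fold lower number from compound 1 to compound 4 (0.73 log units; beyond the scatter) lies beyond the scatter and shows a second aromatic group clear of the ethoxycarbonyl compound. Compound 1 remains a limit and not a number, so that last step is only a bound: the limit of > 1000 nM in this assay, at which 1 of the 4 values shown sits.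

As far as these compounds go, how an unsubstituted phenyl, a pyridine ring or a carboxylic acid would behave at this position remains open. The change from 3-chlorophenyl to 4-fluorophenyl also alters the halogen and its place together, and 4-chlorophenyl or 3-fluorophenyl would be needed to separate the two.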